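Positional isomers of the pyridyl substituent in an aryl-indole series

The source may hold more compounds than are shown below. What is called first, only, known or untested is meant among the compounds shown, and "the series" means these compounds.

Measured compounds:
compound 1 `CN1CCC(c2cn(-c3ccc(F)cc3)c3ccc(-c4ccnn4C)cc23)CC1` 0.32 nM
compound 2 `CN1CCC(c2cn(-c3ccc(F)cc3)c3ccc(-c4ccncc4)cc23)CC1` 10 nM

In an in vitro assay on BHK cells for displacement of a labelled ligand from Alpha-1A adrenergic receptor (Bos taurus), read by scintillation counting, with a stated time of 20 min (on this read-out lower numbers stand for stronger inhibition and higher numbers for weaker inhibition), compound 1 gives 0.32 nM and compound 2 gives 10 nM. Among the measured compounds shown here, compound 2 stands at the highest number of the two, and its only neighbour is compound 1, separated by a 31-fold higher number from compound 1 to compound 2 (1.49 log units; beyond the scatter). For the measured compounds named here, that step, which swaps one aromatic group for another at the same position, is the only measured step available, and it is large.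

Compound 3 `CN1CCC(c2cn(-c3ccc(F)cc3)c3ccc(-c4cccnc4)cc23)CC1` has not been measured. The change from compound 2 is pyridin-3-yl in place of pyridin-4-yl on an aromatic carbon. Going by the values given here, only the step from compound 1 to compound 2 bears on this, and only loosely: it shows that the identity of the ring at this position matters strongly in this assay, but it does not address a shift of the nitrogen within the same six-membered ring. A move of the nitrogen without a change of ring size is expected to matter less than a change of ring, so the step of a 2.0-fold lower number from compound 2 to compound 3 (0.30 log units; within the scatter) is estimated to be modest and within or near the scatter, leaning toward a lower number. The estimate for compound 3 in this assay is 5 nM, with a range of 1 nM to 25 nM.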

Compound 3, inhibition constant: 2.3 nM
Compound 3: middle estimate off by 2.2-fold (0.34 log units), on the high side; the range from low to high includes it.
By their numbers in this assay, from the lowest: compound 1; then compound 3; then compound 2.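

In this assay, moving the ring nitrogen alone, with the heavy atoms and the hydrogen-bond counts of the group unchanged, produces a 4.3-fold lower number from compound 2 to compound 3 (0.64 log units; beyond the scatter) at this aromatic carbon, so pyridin-3-yl and pyridin-4-yl are not interchangeable here. Pyridin-3-yl still does not match the 1-methyl-1H-pyrazol-5-yl group, leaving a 7.2-fold higher number from compound 1 to compound 3 (0.86 log units; beyond the scatter) in this assay, which is a smaller step than the one printed for compound 2 but one that still lies beyond the scatter; the gap to compound 1 therefore depends partly on where the nitrogen sits in the six-membered ring, and part of it remains whichever of these two pyridyl groups is present. Nothing available explains why the position of the nitrogen or the change of ring shifts the number in this way.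

The compounds shown leave open where pyridin-2-yl, a plain phenyl or a pyrazol-5-yl without the methyl group would fall on this scale at the same carbon. Going by these compounds, every comparison here also rests on the shared core and a single read-out, so whether this order of the three groups carries over to a different core remains open as well.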